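Methoxy for Methyl, Tried a Second Time

The source may report more compounds than this note shows. Statements on the series, on what has been measured and on what is new or still open speak of the compounds shown alone.

Compound 1 `CCOC(=O)c1csc2nc(CN3CCN(Cc4ccccc4)CC3)c(-c3ccc(C)cc3)n12` gives 47800 nM in a functional assay on HCT-116 cells (Homo sapiens) for antiproliferative activity, read by MTT assay, with a stated time of 72 h; a higher number here means a weaker inhibitor, a lower number a stronger inhibitor. Compound 2 `CCOC(=O)c1csc2nc(CN3CCN(Cc4ccccc4)CC3)c(-c3ccc(OC)cc3)n12` carries methoxy in place of methyl on an aromatic carbon and gives 19600 nM in this assay; the step is a 2.4-fold lower number from compound 1 to compound 2 (0.39 log units; beyond the scatter). Compound 3 `Cc1ccc(-c2c(CN3CCCCC3)nc3scc(C(=O)O)n23)cc1` rests on another core, and the difference between the two cores is not broken down here. Compound 3 gives 13800 nM in this assay, which lies within the scatter of compound 2 and beyond the scatter of compound 1. Compound 4 `COc1ccc(-c2c(CN3CCCCC3)nc3scc(C(=O)O)n23)cc1` has not been measured; it differs from compound 3 by methoxy in place of methyl on an aromatic carbon, the same change as from compound 1 to compound 2, at the same kind of place. Among the compounds with values here, compound 4 is expected to follow a step of a 2.0-fold lower number from compound 3 to compound 4 (0.29 log units; within the scatter), kept slightly smaller because the only precedent is a 2.4-fold lower number from compound 1 to compound 2 (0.39 log units; beyond the scatter) on a different core. Compound 4 is therefore estimated at 7000 nM, between 3000 nM and 16000 nM.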

Compound 4, half-maximal inhibitory concentration: 84600 nM
The estimate for compound 4 lay 12-fold (1.08 log units) below the measured number; measured number outside the range, above it.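

In this assay, methoxy in place of methyl did not carry over from one core to the other: the new step is a 6.1-fold higher number from compound 3 to compound 4 (0.79 log units; beyond the scatter), opposite in direction to the earlier one. The two steps differ by more than repeated measurement would account for: the same change on two cores in this assay, a 2.4-fold lower number (0.39 log units; beyond the scatter) from compound 1 to compound 2 and a 6.1-fold higher number (0.79 log units; beyond the scatter) from compound 3 to compound 4, 15-fold (1.17 log units) apart, beyond the scatter of two such steps

This does not show which difference between the cores goes with the reversal, and one pair on each core gives no general rule for the series. Open, on these data alone, is whether the step follows the carboxylic acid, which compound 3 and compound 4 carry in place of the ethyl ester, or the amine side chain. Also open, as far as these compounds go, is how an amide at that place, or a chloro group in place of the methoxy, would behave on either core.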